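Undoing an Aromatic Ether Exchange with Cyclobutylmethyl

The compounds below may be only part of what the source reports. "The series", "measured", "known", "first", "only" and "open" are said of these compounds alone.

Among the compounds with values here, compound 3 `C[C@@H](Oc1cc2oc(=O)n(CCC(=O)O)c2cc1Cl)c1cccnn1` gives 631 nM in an assay on HEK293 cells for inhibition of kynurenine 3-monooxygenase (Homo sapiens), read by LC-MS, with a stated time of 20 h (on this read-out lower numbers stand for stronger inhibition and higher numbers for weaker inhibition), the second highest of the three numbers so far. Its nearest neighbour is compound 1 `CCc1cc2oc(=O)n(CCC(=O)O)c2cc1Cl`, which gives 316 nM; the furthest is compound 2 `O=C(O)CCn1c(=O)oc2cc(OCC3CC3)c(Cl)cc21`, which gives 1580 nM. Compound 4 `O=C(O)CCn1c(=O)oc2cc(OCC3CCC3)c(Cl)cc21` differs from compound 3 in one place: a group of 5 heavy atoms (5 carbon; one four-membered non-aromatic ring of carbon only) in place of a group of 8 heavy atoms (6 carbon, 2 nitrogen; one six-membered aromatic ring with 2 hetero atoms), on an oxygen on an aromatic ring. The step that bears on this is a 2.5-fold lower number from compound 2 to compound 3 (0.40 log units; beyond the scatter), in which the cyclopropylmethoxy of compound 2 was replaced by the aromatic group; compound 4 reverses that exchange, with cyclobutylmethyl standing in for cyclopropylmethyl. Compound 4 is therefore expected to show a modest rise in number, a 2.1-fold higher number from compound 3 to compound 4 (0.31 log units; beyond the scatter). The estimate for compound 4 is 1300 nM, with a range from 500 nM to 3500 nM.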

Compound 4, half-maximal inhibitory concentration: 1260 nM
Compound 4: the middle estimate sits 1.0-fold (0.01 log units) above what was measured, within the range that was stated.
By their numbers in this assay, from the lowest: compounds 1, 3, 4 and 2 (each within the scatter of the next, the first and the last beyond it).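

In this assay (this assay), enlarging the ring from cyclopropyl to cyclobutyl leaves the number within the scatter (a 1.3-fold lower number from compound 2 to compound 4 (0.10 log units; within the scatter)), and so does exchanging the aromatic group for cyclobutylmethyl on this oxygen (a 2.0-fold higher number from compound 3 to compound 4 (0.30 log units; within the scatter)). Cyclobutylmethoxy in place of ethyl on the aromatic carbon, by contrast, gives a step beyond the scatter (a 4.0-fold higher number from compound 1 to compound 4 (0.60 log units; beyond the scatter)). Nothing available explains these readings. On these data alone, whether a larger carbon ring such as cyclohexyl, or an amine on the chain bound to this oxygen, would move the number beyond the scatter remains open.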